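The source may report more compounds than this note shows. Statements on the series, on what has been measured and on what is new or still open speak of the compounds shown alone.

Compound 2 `CN(CCN(C)C(=O)n1cccn1)Cc1ccc(OCc2ccccc2)cc1` stands at a limit in an assay on membranes from brain for binding affinity to neutral cholesterol ester hydrolase 1 (Mus musculus), read by fluorescence, with stated times of 1 h and 30 min; a higher number here means a weaker inhibitor, a lower number a stronger inhibitor. In this assay compound 2 gives > 100000 nM, which is a limit rather than a number. Compound 1 `Cc1cnn(C(=O)N(C)CCN(C)Cc2ccc(OCc3ccccc3)cc2)c1` likewise gives only a limit in this assay, > 100000 nM. The step that the two limits leave unreadable from compound 1 to compound 2 therefore cannot be read, because of the limit of > 100000 nM in this assay, at which 2 of the 2 values shown sit. Compound 3 `CN(CCN(C)C(=O)n1cc(C#N)cn1)Cc1ccc(OCc2ccccc2)cc1` differs from compound 2 by cyano in place of hydrogen on an aromatic carbon. Among the compounds with values here, no measured step bears on this change. Compound 3 is therefore expected to remain weak, estimated at 150000 nM with a range of 40000 nM to 1000000 nM. The expected step is a step that the limit leaves unreadable from compound 2 to compound 3.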

Compound 3, half-maximal inhibitory concentration: > 100000 nM
Compound 3: a limit, no number (the forecaster's own chance of this, stated with the estimate: 85%); the middle value is on the limit's open side.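

Within the data shown here, no step among compound 1, compound 2 and compound 3 can be read in this assay, because all three give a limit and not a number: the limit of > 100000 nM in this assay, at which 3 of the 3 values shown sit. The compounds shown leave open whether methyl, hydrogen or cyano on that aromatic carbon makes any difference to inhibitor strength.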